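A few compounds are considered here, and "the series" means these few. Any claim that something is new, unique, unknown or untested is made for them only; others in the source may bear on it.

Measured so far in an in vitro ADME assay on microsomes from liver (Simiiformes); on this read-out lower numbers stand for a shorter-lived compound and higher numbers for a longer-lived compound
- compound 1 `Cc1cc(CCCOc2c(C)cc(-c3noc(C)n3)cc2C)on1` gives 0.45 h
- compound 2 `COc1nc(-c2cc(C)c(OCCCc3cc(C)no3)c(C)c2)no1` gives 0.55 h

Compound 2 stands at 0.55 h within the scatter of compound 1, and no order can be read between them. Among the compounds with values here, compound 3 `Cc1cc(CCCOc2c(C)cc(-c3noc(C(F)F)n3)cc2C)on1` follows from compound 2 with difluoromethyl in place of methoxy on an aromatic carbon as the only change. Within the data shown here, one measured step bears on this, methoxy in place of methyl on an aromatic carbon, a 1.2-fold higher number from compound 1 to compound 2 (0.09 log units; within the scatter) and so within the scatter. Among the measured compounds shown here, no measured compound carries difluoromethyl, so in this assay no step beyond the scatter is expected, and no direction is favoured. The estimated step is a 1.1-fold higher number from compound 2 to compound 3 (0.04 log units; within the scatter) and stays small. Compound 3 is expected at 0.6 h with an estimated range from 0.3 h to 1.3 h for now.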

Compound 3, half-life: 1.42 h
The estimate for compound 3 lay 2.4-fold (0.37 log units) below the measured number, and the stated range ends below it.
By their numbers in this assay, from the lowest: compounds 1 and 2 (each within the scatter of the next); then compound 3.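

The position on the five-membered ring, where methyl and methoxy could not be told apart, does respond to its substituent: in this assay difluoromethyl gives a 2.6-fold higher number from compound 2 to compound 3 (0.41 log units; beyond the scatter) and a 3.2-fold higher number from compound 1 to compound 3 (0.50 log units; beyond the scatter). Both steps are modest, but they set difluoromethyl apart from the other two groups. Nothing at hand accounts for this difference. Open, from the compounds shown here alone, is whether trifluoromethyl or monofluoromethyl on the same carbon would extend or lose the step, and whether a small amine there would behave like methoxy.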